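The source may hold more compounds than are shown below. What is called first, only, known or untested is meant among the compounds shown, and "the series" means these compounds.

Compound 2 `COc1ccc(/C=C/C(=O)N(/N=N/c2cc(C(F)(F)F)ccc2Cl)c2cc(C(F)(F)F)ccc2Cl)cc1OC` gives 28100 nM in a physicochemical assay for solubility (a higher number here means a more soluble compound, a lower number a less soluble compound), the lowest of the two numbers measured, with compound 1 `COc1ccc(/C=C/C(=O)N(/N=N/c2cc(C(F)(F)F)ccc2Cl)c2cc(C(F)(F)F)ccc2Cl)c(OC)c1` giving 84400 nM. Compound 3 `COc1cc(/C=C/C(=O)N(/N=N/c2cc(C(F)(F)F)ccc2Cl)c2cc(C(F)(F)F)ccc2Cl)cc(OC)c1` differs from compound 2 by 3,5-dimethoxyphenyl in place of 3,4-dimethoxyphenyl on a double-bonded chain carbon bound to a double-bonded chain carbon. For the measured compounds named here, the one measured step, a 3.0-fold lower number from compound 1 to compound 2 (0.48 log units; beyond the scatter), also rearranged the two methoxy groups and was modest; it is the only guide, and it does not involve 3,5-dimethoxyphenyl. Compound 3 is therefore expected to sit near compound 2, with no step beyond the scatter confidently predicted, and an estimated 30000 nM in this assay, ranging from 10000 nM to 90000 nM, which would mean a 1.1-fold higher number from compound 2 to compound 3 (0.03 log units; within the scatter).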

Compound 3, solubility: 24100 nM
For compound 3 the middle estimate is 1.2-fold (0.10 log units) above the measured one, and the stated range covers the measured number.
By their numbers in this assay, from the lowest: compounds 3 and 2 (each within the scatter of the next); then compound 1.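

In this assay, 3,5-dimethoxyphenyl in place of 3,4-dimethoxyphenyl gives a 1.2-fold lower number from compound 2 to compound 3 (0.07 log units; within the scatter) and so the two arrangements cannot be told apart at this place on the chain. The 2,4-dimethoxyphenyl of compound 1 now stands apart from both, since 3,5-dimethoxyphenyl in its place gives a 3.5-fold lower number from compound 1 to compound 3 (0.54 log units; beyond the scatter) and this matches the earlier step in kind. No measurement offered here explains why the 2,4-dimethoxyphenyl arrangement differs. The compounds shown carry only dimethoxyphenyl groups at this place, so the number that an amine or a carboxylic acid on that ring would give remains open.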